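This account rests on a few compounds, and the source may have more. Where it says the series, first, only, none or still open, it means among the compounds named here.

Measured in a functional assay on P388 cells (Mus musculus) for cytotoxicity; a higher number here means a weaker inhibitor, a lower number a stronger inhibitor:
Compound 1 `Cc1cc(-c2c(F)cc3c(=O)ccn(C4CC4)c3c2F)cc(C)n1`: 15000 nM
Compound 2 `Cc1cc(-c2c(F)cc3c(=O)c(Cc4ccccc4O)cn(C4CC4)c3c2F)cc(C)n1`: 670 nM

Compound 2 has the lower of the two numbers. Among the compounds with values here, the only measured step, a 22-fold lower number from compound 1 to compound 2 (1.35 log units; beyond the scatter), is large and came with 2-hydroxybenzyl in place of hydrogen on an aromatic carbon. Compound 3 `Cc1cc(-c2c(F)cc3c(=O)c(Cc4cccc(O)c4O)cn(C4CC4)c3c2F)cc(C)n1` differs from compound 2 in one place: hydroxy in place of hydrogen on an aromatic carbon. This is hydroxy in place of hydrogen on an aromatic carbon, taking 2-hydroxybenzyl to 2,3-dihydroxybenzyl. Within the data shown here, the measured step bears on this only indirectly, since it introduced the whole substituent, and no measured step shows the effect of a hydroxy alone. A much smaller move is therefore expected, toward a lower number, and the estimated step is a 2.2-fold lower number from compound 2 to compound 3 (0.35 log units; beyond the scatter). In this assay, compound 3 is expected at 300 nM, with an estimated range of 80 nM to 1000 nM.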

Compound 3, half-maximal inhibitory concentration: 880 nM
Compound 3: the middle estimate sits 2.9-fold (0.47 log units) below what was measured, within the range that was stated.
By their numbers in this assay, from the lowest: compounds 2 and 3 (each within the scatter of the next); then compound 1.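

In this assay, hydroxy in place of hydrogen on the aromatic carbon ortho to a hydroxy group gives a 1.3-fold higher number from compound 2 to compound 3 (0.12 log units; within the scatter), so 2,3-dihydroxybenzyl cannot be told apart from 2-hydroxybenzyl at this position. The large step from the unsubstituted core also holds with the second hydroxy in place: 2,3-dihydroxybenzyl in place of hydrogen gives a 17-fold lower number from compound 1 to compound 3 (1.23 log units; beyond the scatter). No measurement at hand offers an explanation for either step.

The compounds shown leave open how much of the large step belongs to the benzyl group itself and how much to its hydroxy, as a plain benzyl is not among them. Also open, as far as these compounds go, is whether a methoxy or an amine on this aromatic carbon would read the same in this assay as the hydroxy does.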